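Sulfonyl aryl swap on the lowest-clearance member

This account rests on a few compounds, and the source may have more. Where it says the series, first, only, none or still open, it means among the compounds named here.

Three compounds of the series have numbers in an ADME assay on microsomes from liver (Homo sapiens) for metabolic stability, tested at 2.5 uM; on this read-out lower numbers stand for slow clearance and higher numbers for fast clearance. Compound 1 `O=S(=O)(c1ccc(F)c(Cl)c1)c1cnc2cc(F)ccc2c1-c1ccc(Cl)cc1` gives 0.39 mL/min in this assay, the lowest of the three. Compound 3 `COc1ccc(S(=O)(=O)c2cnc3c(F)cccc3c2-c2ccc(Cl)cc2)cc1` gives 1.05 mL/min in this assay, a gap to compound 1 that is beyond the scatter. Compound 2 `COc1ccc(-c2c(S(=O)(=O)c3cc(F)cc(F)c3)cnc3c(F)cccc23)cc1` gives 2.59 mL/min in this assay, the widest gap from compound 1 and also beyond the scatter. Among the compounds with values here, no two of the measured compounds differ in only one place, so no single-point step in this assay has a measured size, and the spread across the three cannot be tied to any one change.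

Compound 4 `O=S(=O)(c1cc(Cl)cc(Cl)c1)c1cnc2cc(F)ccc2c1-c1ccc(Cl)cc1` is not yet measured. It departs from compound 1 by 3,5-dichlorophenyl in place of 3-chloro-4-fluorophenyl on a sulfonyl sulfur. The group that leaves and the group that enters match in heavy-atom count, ring type and count of donors and acceptors; one chlorine enters where a fluorine leaves. With no measured step of this kind in the series, the expectation is a small step, a 1.4-fold higher number from compound 1 to compound 4 (0.15 log units; within the scatter) in this assay, not clearly beyond the scatter. Compound 4 is therefore estimated at 0.55 mL/min in this assay, with a range from 0.25 mL/min to 1.2 mL/min.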

Compound 4, intrinsic clearance in a liver preparation (reported as CLH), per the amount of preparation that the assay uses: 0.13 mL/min
Estimate against measurement, compound 4: 4.2-fold (0.63 log units) above; measured number outside the range, below it.
By their numbers in this assay, from the lowest: compound 4; then compound 1; then compound 3; then compound 2.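

At the aryl group on the sulfonyl sulfur, the series now has its first measured single-place step in this assay: 3,5-dichlorophenyl in place of 3-chloro-4-fluorophenyl gives a 3.0-fold lower number from compound 1 to compound 4 (0.48 log units; beyond the scatter) and lies beyond the scatter. This place therefore responds in this read-out even to a swap that keeps the heavy-atom count, the ring type and the count of donors and acceptors unchanged, with one chlorine entering where a fluorine leaves. Nothing at hand accounts for the direction or the size of this step.

The compounds shown hold only one step at this place, on the core of compound 1, and that step cannot separate the fluorine leaving from the chlorine entering, so it gives no rule for other aryl groups on the sulfonyl sulfur or for other cores. From the compounds shown here alone, it also stays open how the number in this assay would respond to a nitrile or an amine on this aryl ring, or to a pyridine ring in place of it.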